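A few compounds are considered here, and "the series" means these few. Any claim that something is new, unique, unknown or untested is made for them only; others in the source may bear on it.

Measured so far:
- Compound 1, `C/C(=N\NC(=S)Nc1ccccc1I)c1ccccn1`, in a functional assay on U-87MG ATCC cells (Homo sapiens) for cytotoxicity, read by MTT assay, with a stated time of 48 h (a higher number here means a weaker inhibitor, a lower number a stronger inhibitor), compound 1 gives 6.1 nM.
- Compound 2, `CC(=NNC(=S)Nc1ccccc1F)c1ccccn1`, in this assay compound 2 gives 5 nM.

Both compounds share the same core, a thiosemicarbazone built on a pyridine, and differ only in the halogen on the phenyl ring. Compound 2 holds the lowest of the two numbers, but its gap to compound 1 is within the usual scatter of this assay, so the two cannot be told apart on these data alone. Among the measured compounds shown here, no step between measured compounds is given here.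

Compound 3, `C/C(=N\NC(=S)Nc1ccccc1F)c1ccccn1`, is not yet measured. Its difference from compound 2 is this: the two compounds have the same atoms and bonds; at least one stereo element is drawn with a configuration in one of them and without one in the other: 1 of 1 stereo elements differ; a double bond is drawn without a configuration in compound 2 and E in compound 3. In plain terms, compound 3 is the same molecule as compound 2 with the geometry of the double bond drawn out explicitly.

Because compound 2 gives 5 nM and compound 3 has the same atoms and bonds, no step beyond the scatter is expected in this assay. The expected step is a 1.1-fold higher number from compound 2 to compound 3 (0.04 log units; within the scatter). Compound 3 is estimated at 5.5 nM, with a likely range from 2.5 nM to 12 nM.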

Compound 3, half-maximal inhibitory concentration: 5 nM
The estimate for compound 3 lay 1.1-fold (0.04 log units) above the measured number; measured number inside the range.
By their numbers in this assay, from the lowest: compounds 2, 3 and 1 (each within the scatter of the next).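

In this assay, drawing the double bond with a defined E geometry gives no change at the digits printed from compound 2 to compound 3 (within the scatter), so at this place the explicit drawing brings no visible shift in the number. Among the compounds shown here, compound 3 also allows a cleaner halogen comparison than the earlier pair, since compound 1 and compound 2 differ in how the double bond is drawn as well as in the halogen, whereas fluoro in place of iodo on an aromatic carbon is now the only change, giving a 1.2-fold lower number from compound 1 to compound 3 (0.09 log units; within the scatter). These two halogens therefore cannot be told apart here, and what separates compound 2 from compound 3 is only a matter of stereo drawing: the fact that one of compounds 2 and 3 is drawn with a defined configuration and the other without, at the place where they differ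

The data leave open how a compound with the Z geometry at this double bond would read, and whether compound 2 as tested holds one geometry or a mixture. They also leave open what would happen with a chloro, a methoxy or a carboxylic acid group in place of the halogen on the aromatic carbon, since fluoro and iodo alone cover only a small part of the possible groups.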